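The source may report more compounds than this note shows. Statements on the series, on what has been measured and on what is new or still open speak of the compounds shown alone.

Working notes on the series.

Compound 3 `COc1cc2c(Oc3ccc(NC(=O)c4cc(-c5ccc(F)cc5)on4)cc3)ccnc2cc1OCCCN1CCC(C)CC1` gives 2040 nM in a functional assay on PC-3 cells (Homo sapiens) for antiproliferative activity, read by MTT assay, with a stated time of 72 h; on this read-out higher numbers stand for weaker inhibition and lower numbers for stronger inhibition. Among the three measured compounds it holds the second highest number: its nearest neighbour is compound 2 `COc1cc2c(Oc3ccc(NC(=O)c4nc(-c5ccc(F)cc5)no4)cc3)ccnc2cc1OCCCN1CCC(C)CC1`, which gives 1040 nM, and the change a 2.0-fold higher number from compound 2 to compound 3 (0.29 log units; within the scatter) lies within the scatter. Among the measured compounds shown here, the furthest is compound 1 `COc1cc2nccc(Oc3ccc(NC(=O)c4ncc(-c5ccc(F)cc5)o4)cc3)c2cc1OC`, which gives 21900 nM in this assay; no single-point step links compound 1 to compound 3.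

Compound 4 `COc1cc2c(Oc3ccc(NC(=O)c4ncc(-c5ccc(F)cc5)o4)cc3)ccnc2cc1OCCCN1CCC(C)CC1` differs from compound 3 in one place: 5-(4-fluorophenyl)-1,3-oxazol-2-yl in place of 5-(4-fluorophenyl)-1,2-oxazol-3-yl on a carbonyl carbon. For the measured compounds named here, the only measured step that bears on this kind of change is the one from compound 2 to compound 3, an exchange of the five-membered ring on the carbonyl carbon, and it stayed within the scatter. Compound 1 carries the same 5-(4-fluorophenyl)-1,3-oxazol-2-yl group as compound 4 but differs elsewhere, so its value cannot be read as a step. For compound 4 the expected step is therefore a 1.1-fold higher number from compound 3 to compound 4 (0.03 log units; within the scatter), with no change beyond the scatter anticipated, because the step of a 2.0-fold higher number from compound 2 to compound 3 (0.29 log units; within the scatter) was itself inside it. Compound 4 is estimated at 2200 nM, within a range of 700 nM to 7000 nM.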

Compound 4, half-maximal inhibitory concentration: 720 nM
The estimate for compound 4 lay 3.1-fold (0.49 log units) above the measured number; low and high end bracket the measured number.
By their numbers in this assay, from the lowest: compounds 4, 2 and 3 (each within the scatter of the next, the first and the last beyond it); then compound 1.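

Among the compounds shown here, on the carbonyl carbon, two groups with the same atoms joined differently are not interchangeable: in this assay the exchange of 5-(4-fluorophenyl)-1,2-oxazol-3-yl for 5-(4-fluorophenyl)-1,3-oxazol-2-yl gives a 2.8-fold lower number from compound 3 to compound 4 (0.45 log units; beyond the scatter) and is the first ring exchange at this place to pass the scatter, while a 1.4-fold lower number from compound 2 to compound 4 (0.16 log units; within the scatter) stays inside it. The series also gains its first link to compound 1, with a 30-fold lower number from compound 1 to compound 4 (1.48 log units; beyond the scatter) for 2-(4-methylpiperidin-1-yl)ethyl in place of hydrogen, on a saturated chain carbon bound to an oxygen on an aromatic ring. Nothing at hand accounts for either step.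

Open, on these data alone, is whether a morpholine or a dimethylamine in place of the 4-methylpiperidine, or a longer chain, would hold the number of compound 4. Also open, as far as these compounds go, is whether the gap between the two ring arrangements survives a plain phenyl or a 4-chlorophenyl in place of the 4-fluorophenyl.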